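Swapping the Aryl Group on the Carbon Double-Bonded to Nitrogen

A few compounds are considered here, and "the series" means these few. Any claim that something is new, unique, unknown or untested is made for them only; others in the source may bear on it.

Of the compounds shown here, three built on one shared core have been measured in a functional assay on U-87MG ATCC cells (Homo sapiens) for cytotoxicity, read by MTT assay, with a stated time of 72 h; a higher number here means a weaker inhibitor, a lower number a stronger inhibitor. Compound 1 `CN(C)CCn1cnnc1-c1cc(Oc2ccc(NC(=O)N/N=C/c3ccc(Cl)cc3)cc2F)ccn1` carries a 4-chlorophenyl group on a carbon with a double bond to nitrogen, and in this assay compound 1 gives 1370 nM. Compound 2 `Cc1cc(/C=N/NC(=O)Nc2ccc(Oc3ccnc(-c4nncn4CCN(C)C)c3)c(F)c2)cc(C)c1O` carries a 4-hydroxy-3,5-dimethylphenyl group at that place, and compound 2 gives 7710 nM. Compound 3 `COc1ccc(/C=N/NC(=O)Nc2ccc(Oc3ccnc(-c4nncn4CCN(C)C)c3)c(F)c2)c(OC)c1OC` carries a 2,3,4-trimethoxyphenyl group, and compound 3 gives 7650 nM. Among the three, compound 3 stands with the second highest number, indistinguishable from compound 2 (a 1.0-fold lower number from compound 2 to compound 3 (0.00 log units; within the scatter)), while compound 1 sits clearly lower (a 5.6-fold higher number from compound 1 to compound 3 (0.75 log units; beyond the scatter)).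

Compound 4 `CN(C)CCn1cnnc1-c1cc(Oc2ccc(NC(=O)N/N=C/c3c(Cl)cccc3Cl)cc2F)ccn1` is not yet measured. It differs from compound 3 in one place: 2,6-dichlorophenyl in place of 2,3,4-trimethoxyphenyl on a carbon with a double bond to nitrogen. The measured steps that bear on this change are the two that alter the same aryl group, a 5.6-fold higher number from compound 1 to compound 2 (0.75 log units; beyond the scatter) and a 5.6-fold higher number from compound 1 to compound 3 (0.75 log units; beyond the scatter), both moving from a chlorine-bearing phenyl to an oxygen-bearing one and both giving higher numbers. Compound 4 returns to a chlorine-bearing phenyl, now with two chlorines, so a lower number than compound 3 is expected, with some caution because compound 1 gives 1370 nM with a 4-chlorophenyl that is not the same group as the 2,6-dichlorophenyl of compound 4. Compound 4 is therefore estimated at 2500 nM, with a range from 800 nM to 8000 nM, which means an expected step of a 3.1-fold lower number from compound 3 to compound 4 (0.49 log units; beyond the scatter).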

Compound 4, half-maximal inhibitory concentration: > 100000 nM
Compound 4: only a limit was reported (the forecaster's own chance of this, stated with the estimate: 5%); middle value at least 40-fold (1.60 log units) away from the limit.
By their numbers in this assay, from the lowest: compound 1; then compounds 3 and 2 (each within the scatter of the next). At a limit, above all of these: compound 4.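

Compound 4 is reported in this assay only as a limit of the assay, not as a number: the limit of > 100000 nM in this assay, at which 1 of the 4 values shown sits. Chlorine on the phenyl group on a carbon with a double bond to nitrogen therefore does not by itself bring a lower number, as 2,6-dichlorophenyl in place of 4-chlorophenyl gives an at least 72-fold higher number from compound 1 to compound 4 (1.86 log units; beyond the scatter). The change also runs the same way from the two oxygen-bearing aryl groups, with an at least 13-fold higher number from compound 3 to compound 4 (1.11 log units; beyond the scatter) for 2,6-dichlorophenyl in place of 2,3,4-trimethoxyphenyl and an at least 12-fold higher number from compound 2 to compound 4 (1.11 log units; beyond the scatter) for 2,6-dichlorophenyl in place of 4-hydroxy-3,5-dimethylphenyl, so this position allows larger steps than compound 1, compound 2 and compound 3 showed among themselves.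

The compounds shown leave open whether the number of chlorines or the places they occupy on the phenyl group separates compound 4 from compound 1, a question that a 2-chlorophenyl or a 2,6-dimethylphenyl group on the same carbon would address. They also leave open how far past its limit compound 4 lies, and so the full size of these steps.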